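The compounds below may be only part of what the source reports. "The series", "measured", "known", "first", "only" and "open" are said of these compounds alone.

Measured compounds:
- Compound 1, `NC(=O)c1c(NC(=O)c2ccccc2Cl)sc2c1CCN(C(=O)Nc1c(Cl)cccc1Cl)C2` — 24400 nM in a functional assay on MKN-74 cells (Homo sapiens) for antiproliferative activity, with a stated time of 24 h; on this read-out higher numbers stand for weaker inhibition and lower numbers for stronger inhibition
- Compound 2, `NC(=O)c1c(NC(=O)c2ccccc2I)sc2c1CCN(C(=S)Nc1ccccc1Cl)C2` — 17500 nM in this assay

Of the compounds shown here, two have numbers so far. Compound 2 carries the lower of the two numbers in this assay, but the gap to compound 1 is within the usual scatter, so nothing separates them as stronger or weaker; both sit in the weak range of this read-out. Within the data shown here, compound 1 and compound 2 differ in more than one place, and no single step between them can be read.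

Compound 3, `NC(=O)c1c(NC(=O)c2ccncn2)sc2c1CCN(C(=S)Nc1ccccc1Cl)C2`, is not yet measured. Against compound 2 the change is pyrimidin-4-yl in place of 2-iodophenyl on a carbonyl carbon. Among the measured compounds shown here, there is no measured pair that isolates this kind of change, so no size of step is known from the data. Without such a precedent the expectation for compound 3 is a small step, if any, and if there is one it is expected toward a higher number rather than a lower one. Compound 3 is therefore estimated at 25000 nM, with a range from 8000 nM to 80000 nM, which means an expected step of a 1.4-fold higher number from compound 2 to compound 3 (0.15 log units; within the scatter).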

Compound 3, half-maximal inhibitory concentration: 28400 nM
The estimate for compound 3 lay 1.1-fold (0.06 log units) below the measured number; the range from low to high includes it.
By their numbers in this assay, from the lowest: compounds 2, 1 and 3 (each within the scatter of the next).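

Among these compounds, putting pyrimidin-4-yl in place of 2-iodophenyl on a carbonyl carbon gives, in this assay, a 1.6-fold higher number from compound 2 to compound 3 (0.21 log units; within the scatter), the first step that can be read in one place. The change removes the iodine and brings the count of hydrogen-bond acceptors in this group from 0 to 2, yet this read-out does not separate compound 2 from compound 3, so at this position a carbon-only aromatic ring bearing iodine and an aromatic ring with 2 hetero atoms cannot be told apart, and both compounds stay in the weak range. No other data bear on the reason for this result.

Among the compounds shown here, compound 1 differs from compound 2 and from compound 3 in more than one place, so its steps to them cannot be read, and the single step available gives no trend for this position. Open, on these data alone, is whether any other group on this carbonyl carbon, such as an unsubstituted phenyl, an aminophenyl or a carboxyphenyl, would give a number beyond the scatter of those seen so far.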